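Aryloxy swap on the shared core: compound 3 expected

The compounds below may be only part of what the source reports. "The series", "measured", "known", "first", "only" and "open" are said of these compounds alone.

Compound 1 `Cc1cc(-c2cnn3c(NCC4CCOCC4)nc(NC4CCOCC4)nc23)ccc1C(=O)NC1CC1` gives 540 nM in a functional assay on MDA-MB-231 cells (Homo sapiens) for antiproliferative activity; on this read-out lower numbers stand for stronger inhibition of growth and higher numbers for weaker inhibition of growth. Compound 2 `CC(=O)Nc1cccc(Oc2nc(NCC3CCOCC3)n3ncc(-c4ccc(C(=O)NC5CC5)c(C)c4)c3n2)c1` gives 1600 nM, the higher of the two numbers, after the step of a 3.0-fold higher number from compound 1 to compound 2 (0.47 log units; beyond the scatter). Compound 3 `Cc1cc(-c2cnn3c(NCC4CCOCC4)nc(Oc4cccc(F)c4F)nc23)ccc1C(=O)NC1CC1` carries 2,3-difluorophenyl in place of 3-acetamidophenyl on an oxygen on an aromatic ring. Within the data shown here, no measured step shows an exchange of one aryl group for another at this oxygen; the only step at this position, from compound 1 to compound 2, turned an amino group into an aryloxy group and is not a guide here. He therefore expects compound 3 to show a 1.2-fold lower number from compound 2 to compound 3 (0.09 log units; within the scatter), a step not beyond the scatter, with an estimated value of 1300 nM (range 400 nM to 4500 nM).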

Compound 3, concentration for 50% growth inhibition: 12 nM
Compound 3: the middle estimate sits 110-fold (2.03 log units) above what was measured, outside the stated range (below it).
By their numbers in this assay, from the lowest: compound 3; then compound 1; then compound 2.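

In this assay the aryl group on this oxygen proves decisive: exchanging 3-acetamidophenyl for 2,3-difluorophenyl gives a 130-fold lower number from compound 2 to compound 3 (2.12 log units; beyond the scatter) and is a large step. The aryloxy link therefore does not itself weaken growth inhibition, as 2,3-difluorophenoxy in place of (oxan-4-yl)amino gives a 45-fold lower number from compound 1 to compound 3 (1.65 log units; beyond the scatter), opposite in direction to the step to compound 2. No measurement offered here explains this gain. The compounds shown leave open whether both fluorines are needed. Plain phenoxy, 3-fluorophenoxy and 2-fluorophenoxy groups remain untested in this account.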